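Swapping the aryl group on the carbonyl in a chalcone-like series

This account rests on a few compounds, and the source may have more. Where it says the series, first, only, none or still open, it means among the compounds named here.

The measured compounds:
compound 1 `COc1cc(-c2cc(/C=C/C(=O)c3ccc(Cl)c(Cl)c3)[nH]n2)cc(OC)c1OC` with 98%
compound 2 `COc1ccc(C(=O)/C=C/c2cc(-c3cc(OC)c(OC)c(OC)c3)n[nH]2)cc1OC` with 96%
compound 3 `COc1ccc(C(=O)/C=C/c2cc(-c3cc(OC)c(OC)c(OC)c3)n[nH]2)cc1` with 102%

In a functional assay on IGROV-1 cells (Homo sapiens) for cytotoxicity, read by sulforhodamine B assay, with a stated time of 48 h, tested at 0.1 uM (a higher number here means a weaker effect of the compound at the concentration tested, a lower number a stronger effect), compound 3 gives 102%, the highest of the three numbers, yet its gap to each of the others lies within the scatter: a number 4 percentage points higher from compound 1 to compound 3 (within the scatter) and a number 6 percentage points higher from compound 2 to compound 3 (within the scatter). In other words, none of the three compounds shows an effect that stands apart from the rest at this concentration.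

Compound 4 `COc1cc(-c2cc(/C=C/C(=O)c3ccc(F)c(F)c3)[nH]n2)cc(OC)c1OC` has not yet been measured. Relative to compound 3 the change is 3,4-difluorophenyl in place of 4-methoxyphenyl on a carbonyl carbon. Among the compounds with values here, the steps that bear on this are those in which the aryl group on the same carbonyl carbon was exchanged: a number 2 percentage points lower from compound 1 to compound 2 (within the scatter) and a number 4 percentage points higher from compound 1 to compound 3 (within the scatter). Both were within the scatter, so exchanging this aryl group, including a move to or from a dihalogenated ring, has so far left this assay essentially unchanged. Compound 4 is therefore expected to behave alike, with a step of a number 4 percentage points lower from compound 3 to compound 4 (within the scatter) and no change beyond the scatter. For compound 4 the estimate is 98%, with a range from 88% to 108%.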

Compound 4, a percentage reported as activity, at one concentration (the size of the read-out at that concentration, not a potency): 97%
Estimate against measurement, compound 4: 1 percentage points above, within the range that was stated.
By their numbers in this assay, from the lowest: compounds 2, 4, 1 and 3 (each within the scatter of the next).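

In this assay, 3,4-difluorophenyl on the carbonyl carbon behaves like the aryl groups before it, with every new step inside the scatter: a number 5 percentage points lower from compound 3 to compound 4 (within the scatter), a number 1 percentage points higher from compound 2 to compound 4 (within the scatter) and a number 1 percentage points lower from compound 1 to compound 4 (within the scatter). This position has now carried four different substituted phenyl rings, bearing chlorine, fluorine or methoxy, and this single concentration does not separate any of the four compounds. Nothing available here offers an explanation for this sameness.

From the compounds shown here alone, it remains open whether an amine or a carboxylic acid on this ring, or a longer chain in place of the ring, would shift the number beyond the scatter. Also open, going by these compounds, is whether these four compounds would separate at higher concentrations, with a stronger or weaker effect at those concentrations.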